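A few compounds are considered here, and "the series" means these few. Any claim that something is new, unique, unknown or untested is made for them only; others in the source may bear on it.

Measured compounds in a functional assay on A549 cells (Homo sapiens) for antiproliferative activity, read by CCK-8 assay, with a stated time of 72 h; on this read-out higher numbers stand for weaker inhibition and lower numbers for stronger inhibition:
Compound 1, `COc1ccc(C(=O)Nc2cccc(-c3oc4cc(-c5ccc(F)cc5)ccc4c(=O)c3O)c2)cc1`, gives 8700 nM.
Compound 2, `COc1ccccc1C(=O)Nc1cccc(-c2oc3cc(-c4ccc(F)cc4)ccc3c(=O)c2O)c1`, gives 11700 nM.
Compound 3, `Cc1cc(C(=O)Nc2cccc(-c3oc4cc(-c5ccc(F)cc5)ccc4c(=O)c3O)c2)ccc1F`, gives 11500 nM.

Compound 1 has the lowest of the three numbers, but its two neighbours sit very close to it: a 1.3-fold higher number from compound 1 to compound 2 (0.13 log units; within the scatter) and a 1.3-fold higher number from compound 1 to compound 3 (0.12 log units; within the scatter) are both within the scatter, as is a 1.0-fold lower number from compound 2 to compound 3 (0.01 log units; within the scatter). Among the measured compounds shown here, on these numbers, then, no compound can be called more or less active than another; all three behave alike in this assay.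

The next compound is compound 4, `N#Cc1ccc(C(=O)Nc2cccc(-c3oc4cc(-c5ccc(F)cc5)ccc4c(=O)c3O)c2)cc1`. It differs from compound 1 in one place: cyano in place of methoxy on an aromatic carbon. The methoxy leaves and a cyano enters, on an aromatic carbon of a six-membered aromatic ring of carbon only, para to a large group.

For the measured compounds named here, no measured step swaps methoxy for cyano. Going by the values given here, the steps that bear on it are those that reshaped the same aryl group on the carbonyl carbon, from compound 1 to compound 2 and from compound 1 to compound 3, and both stayed within the scatter. Changes on this ring have so far moved the number little, so no step beyond the scatter is expected here either. Compound 4 is therefore estimated at 10000 nM, with a range from 4500 nM to 25000 nM, which amounts to an expected 1.1-fold higher number from compound 1 to compound 4 (0.06 log units; within the scatter).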

Compound 4, half-maximal inhibitory concentration: 2360 nM
The estimate for compound 4 lay 4.2-fold (0.63 log units) above the measured number; measured number below the stated range.
By their numbers in this assay, from the lowest: compound 4; then compounds 1, 3 and 2 (each within the scatter of the next).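

Until now, reshaping the aryl group on the carbonyl carbon had left the number in this assay within the scatter, so this part of the molecule looked insensitive to change. Among the compounds shown here, putting cyano in place of methoxy on the same ring breaks that picture, with the first step beyond the scatter in this set (a 3.7-fold lower number from compound 1 to compound 4 (0.57 log units; beyond the scatter)), so this position does respond to what sits on it, even in a swap of two small groups that are alike in their counted heavy atoms and hydrogen-bond acceptors. The other two neighbours give the same answer (a 4.9-fold lower number from compound 3 to compound 4 (0.69 log units; beyond the scatter) and a 5.0-fold lower number from compound 2 to compound 4 (0.70 log units; beyond the scatter)), which makes compound 4 the most potent of the four, and nothing measured here explains why the cyano compound stands apart.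

The compounds shown leave open whether the gain belongs to cyano itself or would also come with another group in the same place, such as a chlorine atom, a trifluoromethyl, an amine or a carboxylic acid. They also leave open whether cyano would keep this gain elsewhere on the ring.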